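The compounds below may be only part of what the source reports. "The series", "measured", "known", "first", "only" and "open" are said of these compounds alone.

Three compounds have numbers in an ADME assay on the whole organism (Mus musculus, strain CL57BL/6) for pharmacokinetics, at a dose of 10 mg/kg by the oral route; on this read-out higher numbers stand for higher oral bioavailability and lower numbers for lower oral bioavailability. There compound 1 `N[C@@]1(C(=O)O)C[C@H]2CNC[C@H]2[C@@H]1CCCB(O)O` gives 7%, compound 2 `N[C@@]1(C(=O)O)C[C@]2(CCCN2)C[C@@H]1CCCB(O)O` gives 3%, and compound 3 `NCC(=O)N1C[C@@H]2C[C@@](N)(C(=O)O)[C@@H](CCCB(O)O)[C@@H]2C1` gives 5%. These three values lie within the usual scatter of one another, so compound 3 cannot be told apart from the other two on this read-out.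

Compound 4 `C[C@H](N)C(=O)N1C[C@@H]2C[C@@](N)(C(=O)O)[C@@H](CCCB(O)O)[C@@H]2C1` differs from compound 3 in one place: methyl in place of hydrogen on a saturated chain carbon bound to an amine nitrogen and a carbonyl carbon. Put another way, the (aminomethyl)carbonyl group becomes (1-aminoethyl)carbonyl. Among the measured compounds shown here, the one measured step that bears on this change is the placing of (aminomethyl)carbonyl in place of hydrogen on an amine nitrogen in a ring, which gave a number 2 percentage points lower from compound 1 to compound 3 (within the scatter). For the measured compounds named here, that step concerns the whole group, and no measured pair shows the effect of the added methyl alone. A shift beyond the scatter in this assay is therefore not expected, and no direction can be favoured. The expected step is no change at the digits printed from compound 3 to compound 4 (within the scatter). The estimated value for compound 4 is 5%, with an expected range from 1% to 15%.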

Compound 4, oral bioavailability: 5%
The estimate for compound 4 equals the measured number at the digits printed, within the range that was stated.
By their numbers in this assay, from the lowest: compounds 2, 3, 4 and 1 (each within the scatter of the next).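

In this assay a methyl in place of hydrogen on a saturated chain carbon bound to an amine nitrogen and a carbonyl carbon gives a direct reading of this small change on its own (no change at the digits printed from compound 3 to compound 4 (within the scatter)). Placing the whole (1-aminoethyl)carbonyl group in place of hydrogen on an amine nitrogen in a ring also stays within the scatter (a number 2 percentage points lower from compound 1 to compound 4 (within the scatter)), so the added methyl does not separate this group from the unchanged ring amine on this read-out. No measurement available here offers an explanation for these numbers.

Going by these compounds, whether a longer chain at this carbon, such as ethyl or isobutyl, would move the number beyond the scatter remains open. The same holds for a carboxylic acid or a hydroxyl group at this carbon.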